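Shrinking a Tert-Butyl Group to Ethyl

A few compounds are considered here, and "the series" means these few. Any claim that something is new, unique, unknown or untested is made for them only; others in the source may bear on it.

Compound 2 `CC(C)(C)[C@@]1(c2ccccc2)OCC[C@@H](CCNCc2ccccc2)O1` is the reference point. Among the compounds with values here, in an assay on brain for displacement of a labelled ligand from Sigma non-opioid intracellular receptor 1 (Cavia porcellus) (a lower number here means a stronger inhibitor, a higher number a weaker inhibitor), compound 2 gives 128 nM, which is the only plain number measured so far. Compound 1 `CC(C)(C)[C@@]1(c2ccccc2)OCC[C@@H](CCN)O1` carries a bare amine where compound 2 has a benzyl group. In this assay compound 1 reaches only a limit of the assay, > 10000 nM. Within the data shown here, the single measured step, an at least 78-fold lower number from compound 1 to compound 2 (1.89 log units; beyond the scatter), therefore concerns the amine nitrogen and nothing else.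

Compound 3 `CC[C@@]1(c2ccccc2)OCC[C@@H](CCNCc2ccccc2)O1` has not been measured. It differs from compound 2 by ethyl in place of tert-butyl on a saturated ring carbon. Among the measured compounds shown here, no measured step touches that ring carbon, so the data give no direct guide to how this assay responds to a smaller group there. For the measured compounds named here, because an at least 78-fold lower number from compound 1 to compound 2 (1.89 log units; beyond the scatter) is the only documented step and it concerns the nitrogen, the expectation is a modest shift at most, a 2.0-fold higher number from compound 2 to compound 3 (0.29 log units; within the scatter), with wide uncertainty. Compound 3 is estimated at 250 nM, expected between 60 nM and 1000 nM.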

Compound 3, inhibition constant: 20 nM
The estimate for compound 3 lay 13-fold (1.10 log units) above the measured number, outside the stated range (below it).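

The saturated ring carbon between two ring oxygen atoms proves to be a position that matters in this assay, since ethyl in place of tert-butyl gives a 6.4-fold lower number from compound 2 to compound 3 (0.81 log units; beyond the scatter). Within the data shown here, the amine nitrogen is therefore not the only place where the number moves, and on this pair a tert-butyl group with 4 heavy atoms is not needed for a low number, as ethyl with 2 does better. Compound 1 stands at a limit of the assay, so this is the first step that joins two plain numbers: the limit of > 10000 nM in this assay, at which 1 of the 3 values shown sits.

As far as these compounds go, whether methyl on this ring carbon would lower the number further, or propyl would raise it again, stays open. Also open, from the compounds shown here alone, is whether the gain from ethyl holds when a phenethyl group replaces benzyl on the amine nitrogen.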